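A Smaller Sulfonyl Group on an Unresponsive Core

The source may report more compounds than this note shows. Statements on the series, on what has been measured and on what is new or still open speak of the compounds shown alone.

Three compounds share one core and differ only in the chain attached to a saturated ring carbon. Compound 1 `CCOCC12CCC(c3nnc(-c4ccccc4C(F)(F)F)n3C)(CC1)CC2` carries an ethoxy group there. In an assay on CHO-K1 cells for inhibition of 11-beta-hydroxysteroid dehydrogenase type 2 (Homo sapiens), read by scintillation proximity assay (a lower number here means a stronger inhibitor, a higher number a weaker inhibitor), compound 1 gives > 4000 nM, which is a limit of the assay rather than a number. Compound 2 `CCSCCC12CCC(c3nnc(-c4ccccc4C(F)(F)F)n3C)(CC1)CC2` carries (ethylsulfanyl)methyl in place of ethoxy; in this assay compound 2 gives > 4000 nM, again a limit. Compound 3 `CC(C)S(=O)(=O)CCC12CCC(c3nnc(-c4ccccc4C(F)(F)F)n3C)(CC1)CC2` carries (isopropylsulfonyl)methyl; in this assay compound 3 gives > 4000 nM, also a limit. Because (the limit of > 4000 nM in this assay, at which 3 of the 3 values shown sit), the steps a step that the two limits leave unreadable from compound 1 to compound 2, a step that the two limits leave unreadable from compound 1 to compound 3 and a step that the two limits leave unreadable from compound 2 to compound 3 cannot be sized. Compound 3 thus stands at the limit, with nothing to rank it against its two neighbours.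

Compound 4 `Cn1c(-c2ccccc2C(F)(F)F)nnc1C12CCC(CCS(C)(=O)=O)(CC1)CC2` differs from compound 3 by methyl in place of isopropyl on a sulfonyl sulfur. Among the measured compounds shown here, the step from compound 2 to compound 3 is the nearest precedent, since it also changes the chain, yet it too is unreadable. With every known value at the limit, compound 4 is expected to remain at the limit as well, which is to say compound 4 is expected to show a step that the limit leaves unreadable from compound 3 to compound 4. Compound 4 is estimated at 8000 nM in this assay, within 4000 nM to 20000 nM.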

Compound 4, half-maximal inhibitory concentration: > 4000 nM
Compound 4 was reported as a limit (the forecaster's own chance of this, stated with the estimate: 85%); the middle value is on the limit's open side.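

In this assay compound 4 gives > 4000 nM, which is a limit of the assay and not a number. Its steps from compound 1, compound 2 and compound 3 therefore cannot be read: the limit of > 4000 nM in this assay, at which 4 of the 4 values shown sit. The compounds shown leave open whether any chain on the shared core gives a true number, and how these chains would rank.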